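The source may report more compounds than this note shows. Statements on the series, on what has been measured and on what is new or still open speak of the compounds shown alone.

Measured compounds and their values in the cytotoxicity test:

compound 1, `Cc1ccc(C(C)C)c(OCC(=O)NNC(=S)NCc2ccccc2)c1`: 12.6 ug/mL
compound 2, `Cc1ccc(C(C)C)c(OCc2nnc(SCC(=O)Nc3ccc(Cl)cc3)n2Cc2ccccc2)c1`: 65.9 ug/mL
compound 3, `CC(=O)Nc1ccc(OCc2nnc(SCC(=O)Nc3ccc(Cl)cc3)n2Cc2ccccc2)cc1`: 14 ug/mL

The read-out throughout is a toxicity assay on MT4 cells (Homo sapiens) for cytotoxicity, read by MTT assay, with a stated time of 5 days; on this read-out higher numbers stand for lower toxicity in this test and lower numbers for higher toxicity in this test. Among these three, compound 3 sits close to compound 1, the gap between them lying within the usual scatter, while it is separated from compound 2 by a clear margin: the single measured step, a 4.7-fold lower number from compound 2 to compound 3 (0.67 log units; beyond the scatter), is the only one-point change in this set, and it alters the group on the oxygen on the saturated carbon, not the 4-chlorophenyl end of the molecule.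

Compound 4, `CCOC(=O)c1ccc(NC(=O)CSc2nnc(COc3ccc(NC(C)=O)cc3)n2Cc2ccccc2)cc1`, is now to be measured. It differs from compound 3 only in one place: ethoxycarbonyl in place of chloro on an aromatic carbon. For the measured compounds named here, no measured pair in this set bears directly on a change at that position; the step from compound 2 to compound 3 concerns the opposite end of the shared core and so gives no guidance here. With nothing in the data pointing either way, the expectation for this assay is a step no larger than the scatter, a 1.1-fold higher number from compound 3 to compound 4 (0.03 log units; within the scatter), in no firm direction. Compound 4 is therefore estimated at 15 ug/mL, in a range from 6 ug/mL to 40 ug/mL.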

Compound 4, half-maximal cytotoxic concentration: 91.1 ug/mL
Compound 4: the middle estimate sits 6.1-fold (0.78 log units) below what was measured; the measured number lies above the stated range.
By their numbers in this assay, from the lowest: compounds 1 and 3 (each within the scatter of the next); then compounds 2 and 4 (each within the scatter of the next).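

The 4-chlorophenyl end of the molecule turns out not to be silent: in this assay, ethoxycarbonyl in place of chloro, on an aromatic carbon para to a large group, gives a step beyond the scatter (a 6.5-fold higher number from compound 3 to compound 4 (0.81 log units; beyond the scatter)), so compound 4 reads as less toxic in this test than compound 3. For the compounds shown here, until this result, the only one-point change on record lay at the other end of the shared core, on the oxygen (a 4.7-fold lower number from compound 2 to compound 3 (0.67 log units; beyond the scatter)), and it ran in the opposite direction, so a single change at either end of the core is now seen to move the number beyond the scatter. Nothing available explains the rise at this position or says which part of the entering ethoxycarbonyl group, or the loss of chloro, accounts for it.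

As far as these compounds go, with only this one replacement on view, how a carboxylic acid, an amine or a methyl ester would read at the same aromatic carbon remains open. From the compounds shown here alone, it is also open whether the same replacement would give a step of this direction and size with the 2-isopropyl-5-methylphenyl group of compound 2 on the oxygen.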